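Carbonyl-side aryl exchange: compound 3 to compound 4

The source may hold more compounds than are shown below. What is called first, only, known or untested is meant among the compounds shown, and "the series" means these compounds.

Compound 3 `COc1ccc(-c2cc3ccccc3nc2/C=C/C(=O)c2ccc(N)cc2)cc1` gives 9290 nM in a functional assay on H184B5F5/M10 cells (Homo sapiens) for antiproliferative activity, read by XTT assay, with a stated time of 72 h; a higher number here means a weaker inhibitor, a lower number a stronger inhibitor. Compound 1 `COc1ccc(-c2cc3ccccc3nc2/C=C/C(=O)c2ccc(O)cc2)cc1` gives 5690 nM in this assay, and compound 2 `COc1ccc(-c2cc3ccccc3nc2/C=C/C(=O)c2ccc(OC)c(OC)c2)cc1` gives 7240 nM. The steps of a 1.6-fold higher number from compound 1 to compound 3 (0.21 log units; within the scatter) and a 1.3-fold higher number from compound 2 to compound 3 (0.11 log units; within the scatter) both stay within the scatter, so compound 3 is not separated from either of the other two. Compound 4 `COc1ccc(-c2cc3ccccc3nc2/C=C/C(=O)c2cccs2)cc1` carries thiophen-2-yl in place of 4-aminophenyl on a carbonyl carbon. Two measured steps also exchange the group on the carbonyl carbon: a 1.3-fold higher number from compound 1 to compound 2 (0.10 log units; within the scatter) and a 1.3-fold higher number from compound 2 to compound 3 (0.11 log units; within the scatter), neither of which moved this assay beyond the scatter. The expected step of a 1.2-fold lower number from compound 3 to compound 4 (0.06 log units; within the scatter) is therefore none beyond the scatter. Compound 4 is estimated at 8000 nM in this assay, with a range of 3500 nM to 18000 nM.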

Compound 4, half-maximal inhibitory concentration: 7030 nM
For compound 4 the middle estimate is 1.1-fold (0.06 log units) above the measured one; low and high end bracket the measured number.
By their numbers in this assay, from the lowest: compounds 1, 4, 2 and 3 (each within the scatter of the next).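

Exchanging 4-aminophenyl for thiophen-2-yl on the carbonyl carbon replaces the six-membered carbon ring with a five-membered aromatic ring and removes the hydrogen-bond donor, yet this assay separates compound 4 from none of the others (a 1.3-fold lower number from compound 3 to compound 4 (0.12 log units; within the scatter)), (a 1.0-fold lower number from compound 2 to compound 4 (0.01 log units; within the scatter)) and (a 1.2-fold higher number from compound 1 to compound 4 (0.09 log units; within the scatter)). This position therefore accepts a five-membered ring holding sulfur without leaving the scatter, so all four carbonyl-side groups remain unseparated. No available evidence accounts for this flat result.

Open, from the compounds shown here alone, is whether a pyridine ring, a carboxylic acid or a saturated amine such as piperidine on the carbonyl carbon would move the number beyond the scatter.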